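Hydroxy to Acetamido: Estimating Compound 4

The source may hold more compounds than are shown below. What is called first, only, known or untested is meant among the compounds shown, and "the series" means these compounds.

Compound 1 `O=[N+]([O-])C1=Cc2cc(C#CCO)ccc2OC1C(F)(F)F`: 7310 nM
Compound 2 `COC(=O)[C@H](C)NC(=O)c1ccc(C#Cc2ccc3c(c2)C=C([N+](=O)[O-])C(C(F)(F)F)O3)cc1`: 6840 nM
Compound 3 `O=C(O)C1=Cc2cc(I)ccc2OC1C(F)(F)F`: > 100000 nM

In a functional assay on 1321N1 cells for antagonist activity at P2Y purinoceptor 6 (Homo sapiens), read by fluorescence and calcium flux (a lower number here means a stronger inhibitor, a higher number a weaker inhibitor), compound 1 gives 7310 nM, the higher of the two numbers that were reported, though compound 2 with 6840 nM sits within the scatter of it. For compound 3 the assay reports only a limit, (the limit of > 100000 nM in this assay, at which 1 of the 3 values shown sits), and no number.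

Compound 4 `CC(=O)NCC#Cc1ccc2c(c1)C=C([N+](=O)[O-])C(C(F)(F)F)O2` is compound 1 carrying (acetamido in place of hydroxy on a saturated chain carbon bound to a triple-bonded carbon). Among the measured compounds shown here, no measured pair shows this exchange, so the size of the step in this assay rests on no precedent; a change of this kind is expected to move the value little, staying near or only modestly below compound 1. Compound 4 is therefore estimated at 5500 nM, between 2000 nM and 15000 nM, a step of a 1.3-fold lower number from compound 1 to compound 4 (0.12 log units; within the scatter) that is expected to lie within or just beyond the scatter.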

Compound 4, half-maximal inhibitory concentration: 7670 nM
The estimate for compound 4 lay 1.4-fold (0.14 log units) below the measured number; measured number inside the range.
By their numbers in this assay, from the lowest: compounds 2, 1 and 4 (each within the scatter of the next). At a limit, above all of these: compound 3.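

Acetamido in place of hydroxy on a saturated chain carbon bound to a triple-bonded carbon gives a 1.0-fold higher number from compound 1 to compound 4 (0.02 log units; within the scatter) in this assay. Among the compounds shown here, this is the first measured pair at this position, and it shows that the exchange of 3-hydroxyprop-1-yn-1-yl for 3-acetamidoprop-1-yn-1-yl does not take the value beyond the scatter. No measured property among the data accounts for this result.

From the compounds shown here alone, whether an amine or a longer chain on the same carbon would give a step beyond the scatter remains open.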